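The source may report more compounds than this note shows. Statements on the series, on what has been measured and on what is new or still open speak of the compounds shown alone.

Compound 3, `CC(C)Cn1c(=O)[nH]c(C(=O)N[C@H]2CC[C@@H](c3ccccc3)CC2)c(O)c1=O`, gives 48000 nM in an assay on isolated protein for inhibition of endothelial lipase (Homo sapiens), read by LC-MS, with a stated time of 2 h, in the presence of a further agent that is not named here; a higher number here means a weaker inhibitor, a lower number a stronger inhibitor. It has the lowest number of the three compounds measured, but its gap to compound 1, `Nc1c(C(=O)N[C@@H]2CC[C@H](c3ccccc3)c3ccccc32)[nH]c(=O)[nH]c1=O`, which gives 76000 nM in this assay, and to compound 2, `Nc1c(C(=O)N[C@@H]2CCc3cc(OCc4ccccc4)ccc32)[nH]c(=O)[nH]c1=O`, which gives 80000 nM in this assay, lies within the usual scatter, so no order among the three can be drawn from these numbers.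

Compound 4, `O=C(N[C@H]1CC[C@@H](c2ccccc2)CC1)c1[nH]c(=O)n(CCO)c(=O)c1O`, has not yet been measured. It differs from compound 3 in one place: hydroxymethyl in place of isopropyl on a saturated chain carbon bound to an aromatic nitrogen. Among the measured compounds shown here, no pair of measured compounds shows the effect of this change, and the three measured compounds cluster within the scatter of one another with no change at the chain on the aromatic nitrogen among them.

With nothing to steer the expectation either way, the step from compound 3 to compound 4 is expected to stay within the scatter, a 1.0-fold higher number from compound 3 to compound 4 (0.02 log units; within the scatter). Compound 4 is therefore estimated to give 50000 nM in this assay, with a range from 20000 nM to 130000 nM.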

Compound 4, half-maximal inhibitory concentration: > 143000 nM
Compound 4: a limit, no number; the forecaster's own chance of this, stated with the estimate: 20%; middle value at least 2.8-fold (0.45 log units) away from the limit.
By their numbers in this assay, from the lowest: compounds 3, 1 and 2 (each within the scatter of the next). At a limit, above all of these: compound 4.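

In this assay, compound 4 gives > 143000 nM, which is a limit of the assay and not a number. Among the compounds shown here, the change of isopropyl to hydroxymethyl on a saturated chain carbon bound to an aromatic nitrogen gives an at least 2.9-fold higher number from compound 3 to compound 4 (0.47 log units; beyond the scatter), so this place, which no earlier pair of compounds had probed, proves sensitive to what stands on it, and of the two chains only the isobutyl chain of compound 3 gives a number. The reading of the 2-hydroxyethyl compound therefore marks the top of the measured range: the limit of > 143000 nM in this assay, at which 1 of the 4 values shown sits.

The compounds shown leave open whether the step follows from the hydroxyl group or from the loss of the branched end of the chain, which an unbranched propyl or a methoxyethyl chain would separate. Going by these compounds, how a longer alkyl chain, an amine or a carboxylic acid at this place would read in this assay also remains open.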